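Azido in place of amino on the side chain of compound 1

The compounds below may be only part of what the source reports. "The series", "measured", "known", "first", "only" and "open" are said of these compounds alone.

Measured so far:
compound 1, `NCC(O)Cn1c(=O)n(C2OC(CO)[C@@H](O)[C@H]2O)c2nc(N)nc(O)c21`, 110%
compound 2, `C=CCn1c(=S)n([C@@H]2O[C@H](CO)[C@H]3OC(C)(C)O[C@H]32)c2nc(N)nc(O)c21`, 89%
compound 3, `CCCn1c(=O)n(C2OC(COP(=O)(O)O)[C@@H](O)[C@H]2O)c2nc(N)nc(O)c21`, 76%

Read-out throughout is a functional assay on the whole organism (B cells) with Mus musculus as the target; on this read-out higher numbers stand for larger maximal responses and lower numbers for smaller maximal responses. Compound 1 stands highest of the three numbers. The nearest is compound 2, whose value lies lower by a gap beyond the usual scatter; compound 3 lies furthest, lower by a gap that is also beyond the scatter. Among the compounds with values here, no two of the measured compounds differ at a single place, so no single-point step has been measured, and nothing is known yet about how a change on the side chain moves this read-out.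

Compound 4, `[N-]=[N+]=NCC(O)Cn1c(=O)n(C2OC(CO)[C@@H](O)[C@H]2O)c2nc(N)nc(O)c21`, differs from compound 1 in one place: azido in place of amino on a saturated chain carbon, two bonds along the chain from an oxygen on a saturated carbon. Within the data shown here, with no measured step to lean on, the size of the change for compound 4 can only be guessed from the modest nature of the swap; the expectation is a step from compound 1 of a number 10 percentage points lower from compound 1 to compound 4 (within the scatter), either no change beyond the scatter or a slight fall. The estimate for compound 4 in this assay is therefore 100%, with a range from 80% to 120%.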

Compound 4, largest response reached (reported as maximal response), in percent of the reference or control that the assay uses: 91%
Compound 4: middle estimate off by 9 percentage points, on the high side, within the range that was stated.
By their numbers in this assay, from the lowest: compound 3; then compounds 2 and 4 (each within the scatter of the next); then compound 1.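

In this assay, within the data shown here, azido in place of amino on the 3-amino-2-hydroxypropyl side chain gives a number 19 percentage points lower from compound 1 to compound 4 (beyond the scatter), the only single-place step so far and a first sign that this position, on a saturated chain carbon, two bonds along the chain from an oxygen on a saturated carbon, is not indifferent to what it carries. The amino group is nevertheless not needed for a substantial response on this read-out, since compound 4, which lacks it, still gives 91%. No measurement on hand connects this step to any property of either group.

As far as these compounds go, whether the fall follows from losing amino or from bringing in azido stays open, and a hydroxyl group or an acetamido group at the same place on the side chain, with the rest of compound 1 unchanged, would help to tell the two apart. From the compounds shown here alone, compound 2 and compound 3 differ from compound 1 in more than one place, so it also remains open whether this step would hold with their other changes present.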